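The source may report more compounds than this note shows. Statements on the series, on what has been measured and on what is new or still open speak of the compounds shown alone.

Measured compounds in an assay on isolated protein for inhibition of Ectonucleotide pyrophosphatase/phosphodiesterase family member 1 (Homo sapiens); on this read-out lower numbers stand for stronger inhibition and higher numbers for weaker inhibition:
compound 1 `COc1ccc(NC(=O)CSc2nc3cnccc3[nH]2)cc1OC` gives 44.2 nM
compound 2 `COc1ccc(NC(=O)CSc2nc3c(OC(C)C)nc(N)nc3[nH]2)cc1OC` gives 11000 nM

Going by the values given here, compound 2 holds the higher of the two numbers in this assay; its only neighbour is compound 1, whose number is far lower, a gap well beyond the scatter. Among the compounds with values here, compounds 1 and 2 differ from each other in more than one place on the shared core, so no single structural step between them is established, and the pair says nothing about any one change on its own.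

Compound 3 `COc1ccc(NC(=O)CSc2nc3c(SC)nc(N)nc3[nH]2)cc1OC` is not yet measured. It differs from compound 2 in one place: methylsulfanyl in place of isopropoxy on an aromatic carbon. Within the data shown here, no measured pair isolates this change. For compound 3 only a small step is expected, a 1.6-fold lower number from compound 2 to compound 3 (0.20 log units; within the scatter), and the direction cannot be fixed from the numbers at hand. Compound 3 is therefore expected to give about 7000 nM in this assay, within a range of 1500 nM to 30000 nM.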

Compound 3, inhibition constant: 3650 nM
Estimate against measurement, compound 3: 1.9-fold (0.28 log units) above, and the stated range covers the measured number.
By their numbers in this assay, from the lowest: compound 1; then compound 3; then compound 2.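

In this assay, going by these compounds alone, methylsulfanyl in place of isopropoxy on this aromatic carbon, next to the ring nitrogen, comes with a 3.0-fold lower number from compound 2 to compound 3 (0.48 log units; beyond the scatter), the first single-place step and a modest one. The number at this position therefore depends on the group it carries, at least for these two groups. This one pair cannot separate the shorter chain from the exchange of oxygen for sulfur, and no measurement shown gives a reason for the step.

From the compounds shown here alone, whether methoxy, ethylsulfanyl or an amine on this carbon would give a number nearer compound 2 or compound 3 remains open. The contribution of the amino group on the shared core is also open, since no single step shown isolates it.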